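The source may report more compounds than this note shows. Statements on the series, on what has been measured and on what is new or still open speak of the compounds shown alone.

- Compound 1 `C#CCSc1nc(Nc2ccccc2)c2ccncc2n1`: > 80000 nM, a limit of the assay and not a number
- Compound 2 `CCSc1nc(Nc2cccc(OC)c2)c2ccncc2n1`: 7150 nM

Among the compounds with values here, in a functional assay on PC-3 cells (Homo sapiens) for inhibition, read by MTT assay, with a stated time of 72 h (a higher number here means a weaker inhibitor, a lower number a stronger inhibitor), compound 2 gives 7150 nM, the only exact number so far. Compound 3 `C/C=C/Sc1nc(Nc2cccc(OC)c2)c2ccncc2n1` has prop-1-en-1-yl in place of ethyl on a sulfur. Within the data shown here, no measured pair of compounds shows what a change at this place does. Resting on compound 2 at 7150 nM alone, no step beyond the usual scatter is expected in this assay. The expected change is a 1.0-fold lower number from compound 2 to compound 3 (0.01 log units; within the scatter). Compound 3 is estimated at 7000 nM, within an expected range of 2000 nM to 25000 nM.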

Compound 3, half-maximal inhibitory concentration: 6790 nM
Compound 3: the middle estimate sits 1.0-fold (0.01 log units) above what was measured; the measured number falls inside the stated range.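

Putting prop-1-en-1-yl in place of ethyl on the sulfur gives, in this assay, a 1.1-fold lower number from compound 2 to compound 3 (0.02 log units; within the scatter). Within the data shown here, this is the first measured pair at this place, and compound 2 and compound 3 cannot be told apart, so a double bond outside aromatic rings on this chain makes no readable difference here. Among these compounds, nothing measured so far bears on why the two compounds read alike.

On these data alone, whether an amine, a carboxylic acid or a longer chain on this sulfur would give a different number remains open. So does whether the same swap would read alike with another group on the rest of the molecule.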